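The compounds below may be only part of what the source reports. "The series", "measured", "known", "first", "only" and "open" are said of these compounds alone.

Three compounds have been measured in an assay on isolated protein for inhibition of glutathione S-transferase Mu 2 (Homo sapiens), with a stated time of 10 min; a lower number here means a stronger inhibitor, a higher number a weaker inhibitor:

compound 1, `O=C(CCC(=O)OCCCCCCSc1ccc([N+](=O)[O-])c2nonc12)Nc1ccccc1`, 700 nM
compound 2, `Cc1ccccc1NC(=O)CCC(=O)OCCCCCCSc1ccc([N+](=O)[O-])c2nonc12`, 440 nM
compound 3, `O=C(CCC(=O)OCCCCCCSc1ccc([N+](=O)[O-])c2nonc12)Nc1cccc(Cl)c1`, 1100 nM

Compound 3 gives the highest of these three numbers: a 1.6-fold higher number from compound 1 to compound 3 (0.20 log units; within the scatter), a gap within the scatter, and a 2.5-fold higher number from compound 2 to compound 3 (0.40 log units; beyond the scatter), a gap beyond it. Compound 4, `O=C(CCC(=O)OCCCCCCSc1ccc([N+](=O)[O-])c2nonc12)Nc1ccc(Br)cc1`, has not yet been measured in this assay. It differs from compound 3 in one place: 4-bromophenyl in place of 3-chlorophenyl on an amide-type nitrogen. The measured steps that come closest are a 1.6-fold higher number from compound 1 to compound 3 (0.20 log units; within the scatter), where chloro replaces hydrogen on an aromatic carbon, and a 1.6-fold lower number from compound 1 to compound 2 (0.20 log units; within the scatter), where methyl does so; neither moved the number beyond the scatter. Among the measured compounds shown here, no measured step exchanges a 3-chlorophenyl for a 4-bromophenyl, and no measured step exchanges chloro for bromo, so the direction of this change cannot be read from the data. For compound 4 the expected step is a 1.1-fold lower number from compound 3 to compound 4 (0.04 log units; within the scatter), within the scatter. The estimate for compound 4 in this assay is 1000 nM, with a range from 400 nM to 2500 nM.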

Compound 4, half-maximal inhibitory concentration: 32000 nM
For compound 4 the middle estimate is 32-fold (1.51 log units) below the measured one; measured number above the stated range.
By their numbers in this assay, from the lowest: compounds 2, 1 and 3 (each within the scatter of the next, the first and the last beyond it); then compound 4.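

In this assay, the aryl group on the amide-type nitrogen turns out not to be a place where changes are always small: a 46-fold higher number from compound 1 to compound 4 (1.66 log units; beyond the scatter), where bromo replaces hydrogen, whereas chloro and methyl on the same aromatic ring had moved the number only within the scatter. The other two steps are large as well, a 29-fold higher number from compound 3 to compound 4 (1.46 log units; beyond the scatter) and a 73-fold higher number from compound 2 to compound 4 (1.86 log units; beyond the scatter), so 4-bromophenyl stands well apart from the phenyl, 2-methylphenyl and 3-chlorophenyl groups. Nothing available here explains this sharp loss of inhibition.

The compounds shown leave open whether the bromine itself or where it sits on the ring carries the change, a question that a 4-chlorophenyl or a 3-bromophenyl group on the same nitrogen would separate. As far as these compounds go, whether a 4-methylphenyl group would behave like 4-bromophenyl also stays open.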